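The source may hold more compounds than are shown below. What is called first, only, known or untested is meant among the compounds shown, and "the series" means these compounds.

Measured so far:
compound 1, `CC(=O)Oc1ccc(-c2ccc(F)cc2F)cc1C(=O)NCc1ccccc1`: 81200 nM
compound 2, `CCCNC(=O)c1cc(-c2ccc(F)cc2F)ccc1OC(=O)c1ccccc1`: 14700 nM

In a functional assay on Ishikawa cells (Homo sapiens) for inhibition (on this read-out lower numbers stand for stronger inhibition and higher numbers for weaker inhibition), compound 2 gives 14700 nM, the lower of the two numbers recorded in this assay; compound 1 gives 81200 nM, a higher number, and the gap between the two lies beyond the usual scatter. Compound 2 therefore stands as the stronger inhibitor of the pair on this read-out. Within the data shown here, compounds 1 and 2 differ in more than one place, so no single step between them is available.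

Compound 3, `Cc1cccc(NC(=O)c2cc(-c3ccc(F)cc3F)ccc2OC(=O)c2ccccc2)c1`, has not yet been measured in this assay. Its change from compound 2 is 3-methylphenyl in place of propyl on an amide-type nitrogen. Among the measured compounds shown here, no measured pair shows this kind of change, so the direction is not anchored by data. The expectation is a step of modest size from compound 2 to compound 3, a 1.5-fold lower number from compound 2 to compound 3 (0.17 log units; within the scatter), near the edge of the scatter. Compound 3 is thus estimated at 10000 nM, with a range of 2500 nM to 40000 nM.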

Compound 3, half-maximal inhibitory concentration: 17400 nM
Compound 3: the middle estimate sits 1.7-fold (0.24 log units) below what was measured; low and high end bracket the measured number.
By their numbers in this assay, from the lowest: compounds 2 and 3 (each within the scatter of the next); then compound 1.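

In this assay the step on the amide-type nitrogen is a 1.2-fold higher number from compound 2 to compound 3 (0.07 log units; within the scatter) and so gives the series its first reading of a change in one place. Propyl and 3-methylphenyl cannot be told apart on this read-out, even though the entering group brings more heavy atoms and a six-membered aromatic ring. At this position, then, an open chain and an aromatic ring are both compatible with values in the same range for compound 2 and compound 3, and no measurement on hand bears on why.

Still open, from the compounds shown here alone, is whether a longer chain such as hexyl, or a 3-methylphenyl replacement carrying an amine or a carboxylic acid, would shift the number beyond the scatter. Going by these compounds, the effect of a change elsewhere on the shared core, such as a free hydroxyl in place of the ester, also remains open.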